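From 4-ethoxyphenyl to 3-chlorophenyl in a cytotoxicity test

A few compounds are considered here, and "the series" means these few. Any claim that something is new, unique, unknown or untested is made for them only; others in the source may bear on it.

- Compound 1 `C=C[C@@](C)(/C=C/c1ccc(O)cc1)CC/C=C/C(=O)OCc1ccccc1` in an ADME assay on HEK293 cells (Homo sapiens) for cytotoxicity, with a stated time of 72 h (on this read-out higher numbers stand for an effect only at larger amounts of compound and lower numbers for an effect already at smaller amounts), gives > 36600 nM (a limit)
- Compound 2 `CCOc1ccc(/C=C/[C@@](C)(/C=C/c2ccc(O)cc2)CCC=C(C)C)cc1` in this assay gives > 36600 nM (a limit)

A limit like this is not a true number. Compound 2 stands at the limit of > 36600 nM in this assay, at which 2 of the 2 values shown sit, and so has no exact value on this scale.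

The next compound to be tested is compound 3 `CC(C)=CCC[C@](C)(/C=C/c1ccc(O)cc1)/C=C/c1cccc(Cl)c1` and it differs from compound 2 in one place. On a double-bonded chain carbon bound to a double-bonded chain carbon, 3-chlorophenyl stands in place of 4-ethoxyphenyl (3-chlorophenyl in place of 4-ethoxyphenyl on a double-bonded chain carbon bound to a double-bonded chain carbon).

Among the compounds with values here, no pair of measured compounds differs in just one place, so no measured step can serve as a guide for this swap. Within the data shown here, the only firm guide is that compound 1 and compound 2 share the limit of > 36600 nM in this assay, at which 2 of the 2 values shown sit, and this points to compound 3 staying near that limit too. In this assay the estimated change is a step that the limit leaves unreadable from compound 2 to compound 3 and no shift beyond the usual scatter is expected, in either direction. For compound 3 the expected value is 40000 nM with an estimated range from 15000 nM to 80000 nM in this test.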

Compound 3, half-maximal effective concentration: > 36600 nM
Compound 3 was reported as a limit; the forecaster's own chance of this, stated with the estimate: 70%; the middle value is on the limit's open side.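

In this assay compound 3 gives > 36600 nM, which is a limit and not an exact number. Compound 2 also carries a limit, so no step can be read for the swap from compound 2 to compound 3. The compounds shown leave open whether any of them truly differs from the others, as they all share one result: the limit of > 36600 nM in this assay, at which 3 of the 3 values shown sit.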